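The source may report more compounds than this note shows. Statements on the series, on what has been measured and on what is new or still open speak of the compounds shown alone.

- Compound 1 `COc1cccc(C(=O)n2c(-c3cn(C)c4ccc(OC)cc34)nc3ccccc32)c1` gives 11700 nM
- Compound 2 `COc1ccc(C(=O)n2c(-c3cn(C)c4ccc(OC)cc34)nc3ccccc32)cc1` gives 12800 nM
- Compound 3 `COc1ccc2c(c1)c(-c1nc3ccccc3n1C(=O)c1ccc(OC)c(OC)c1)cn2C` gives 5100 nM

In a functional assay on HepG2 cells (Homo sapiens) for inhibition, read by MTT assay, with a stated time of 24 h (on this read-out higher numbers stand for weaker inhibition of growth and lower numbers for stronger inhibition of growth), compound 3 has the lowest number of the three, and the gaps to compound 1 and compound 2 are both beyond the scatter. Compound 4 `COc1ccc2c(c1)c(-c1nc3ccccc3n1C(=O)c1ccccc1Br)cn2C` is still unmeasured. It carries 2-bromophenyl in place of 3,4-dimethoxyphenyl on a carbonyl carbon.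

Among the measured compounds shown here, three measured steps bear on this change. Adding a methoxy gave a 2.3-fold lower number from compound 1 to compound 3 (0.36 log units; beyond the scatter) and also a 2.5-fold lower number from compound 2 to compound 3 (0.40 log units; beyond the scatter), both modest. Swapping 3-methoxyphenyl for 4-methoxyphenyl gave a 1.1-fold higher number from compound 1 to compound 2 (0.04 log units; within the scatter), so that swap made no clear difference. For the measured compounds named here, no measured compound carries bromine, so the data say nothing direct about it, and the range must stay wide.

With 3,4-dimethoxyphenyl gone, a modest rise toward compound 1 (11700 nM) seems the likeliest outcome. The expected change is a 2.0-fold higher number from compound 3 to compound 4 (0.29 log units; within the scatter). For compound 4 the estimate in this assay is 10000 nM (expected range 3500 nM to 30000 nM) .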

Compound 4, concentration for 50% growth inhibition: 54200 nM
Estimate against measurement, compound 4: 5.4-fold (0.73 log units) below, outside the stated range (above it).
By their numbers in this assay, from the lowest: compound 3; then compounds 1 and 2 (each within the scatter of the next); then compound 4.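

In this assay, the group on the carbonyl carbon can shift the number much further than adding one methoxy did: 2-bromophenyl in place of 3,4-dimethoxyphenyl gives an 11-fold higher number from compound 3 to compound 4 (1.03 log units; beyond the scatter). The swaps from the single-methoxy groups point the same way, with a 4.2-fold higher number from compound 2 to compound 4 (0.63 log units; beyond the scatter) and a 4.6-fold higher number from compound 1 to compound 4 (0.67 log units; beyond the scatter), and no listed compound goes against this. Among these four compounds, then, compound 4 is the weakest growth inhibitor, and each methoxy-bearing group gives a lower number than 2-bromophenyl.

Nothing available here explains why this swap raises the number. On these data alone, the swap removes the methoxy groups and brings in bromine at once, so their separate shares stay open, and a plain phenyl group or a phenyl carrying an amine would help to tell them apart.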